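The compounds below may be only part of what the source reports. "The series", "measured", "known", "first", "only" and "open" are said of these compounds alone.

Working notes on the dithiocarbamate series. In a functional assay on MGC-803 cells (Homo sapiens) for antiproliferative activity, read by CCK-8 assay, with a stated time of 72 h, tested at 2 uM (on this read-out higher numbers stand for a stronger effect at the one concentration tested and lower numbers for a weaker effect), compound 1 `Nc1ccccc1NC(=O)c1ccc(CSC(=S)N2CCN(C(c3ccccc3)c3ccccc3)CC2)cc1` gives 9.8%, compound 2 `Nc1ccccc1NC(=O)c1ccc(CSC(=S)N2CCN(c3cccnc3)CC2)cc1` gives 27.6%, and compound 3 `Nc1ccccc1NC(=O)c1ccc(CSC(=S)N2CCc3cc(Cl)ccc32)cc1` gives 57.7%. Compound 2 stands second of the three: its value lies beyond the scatter above that of compound 1 and beyond the scatter below that of compound 3. Compound 4 `Cc1ccc(N2CCN(C(=S)SCc3ccc(C(=O)Nc4ccccc4N)cc3)CC2)cc1` is not yet measured in this assay. It differs from compound 2 by 4-methylphenyl in place of pyridin-3-yl on an amine nitrogen in a ring. Going by the values given here, no measured pair shows this change, so its size cannot be read off; the three values only show that the group on the ring nitrogen matters. A small step upward, possibly within the scatter, is expected from compound 2 to compound 4 a number 5.4 percentage points higher from compound 2 to compound 4 (within the scatter). Compound 4 is therefore estimated at 33%, between 12% and 55%.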

Compound 4, a percentage reported as inhibition, at one concentration (the size of the read-out at that concentration, not a potency): 33.4%
For compound 4 the middle estimate is 0.4 percentage points below the measured one; low and high end bracket the measured number.
By their numbers in this assay, from the lowest: compound 1; then compounds 2 and 4 (each within the scatter of the next); then compound 3.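

In this assay, 4-methylphenyl in place of pyridin-3-yl on the amine nitrogen in the ring gives a number 5.8 percentage points higher from compound 2 to compound 4 (within the scatter). At this position, then, a six-membered aromatic ring of carbon only and one with a hetero atom cannot be told apart here, although the change removes a hydrogen-bond acceptor. No evidence on the cause of this result is available.

Still open, from the compounds shown here alone, is how plain phenyl would compare, since the ring atom and the methyl change together in this step. Also open, going by these compounds, is whether a carboxylic acid or an amine in place of the methyl would stay within the scatter of compound 4.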